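Removing trifluoromethyl from compound 3

A few compounds are considered here, and "the series" means these few. Any claim that something is new, unique, unknown or untested is made for them only; others in the source may bear on it.

In a physicochemical assay for solubility, read by HPLC, in phosphate buffer, measured as kinetic solubility, at pH 7.4 (a lower number here means a less soluble compound, a higher number a more soluble compound), compound 1 (`CCC(=O)c1cc(-c2ccc(Cl)cc2)n(-c2ccc(S(C)(=O)=O)cc2)c1C`) gives 4800 nM and compound 2 (`CCCc1cc(-c2ccccc2)n(-c2ccc(S(N)(=O)=O)cc2)c1C`) gives 3800 nM while compound 3 (`CCC(=O)c1cc(-c2ccc(S(N)(=O)=O)cc2)n(-c2ccc(C(F)(F)F)cc2)n1`) gives 7500 nM on the same scale. Compound 3 thus stands within the usual scatter of both others, and the three numbers cannot be told apart. Compound 4 (`CCC(=O)c1cc(-c2ccc(S(N)(=O)=O)cc2)n(-c2ccccc2)n1`) carries hydrogen in place of trifluoromethyl on an aromatic carbon. Going by the values given here, no measured pair differs in one place alone, so nothing here sizes this change directly. In this assay a moderate rise is expected, the estimated step being a 2.4-fold higher number from compound 3 to compound 4 (0.38 log units; beyond the scatter) in the direction of a higher number. For compound 4 the estimated value is 18000 nM with an expected range from 7000 nM to 45000 nM in repeated measurements.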

Compound 4, solubility: 47200 nM
Beside the measured number, compound 4's estimate is 2.6-fold (0.42 log units) below it; the whole stated range lies below it.
By their numbers in this assay, from the lowest: compounds 2, 1 and 3 (each within the scatter of the next); then compound 4.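

In this assay, going by these compounds alone, hydrogen in place of trifluoromethyl on an aromatic carbon gives a 6.3-fold higher number from compound 3 to compound 4 (0.80 log units; beyond the scatter) in the first pair here that differs in one place alone. The earlier compounds shown here could not be told apart and sized no single change, whereas this position, para to a large group, now carries a step beyond the scatter. No measured property accompanies this step, so the result stands without an explanation.

As far as these compounds go, whether a methoxy group, a nitrile or an amine at this position would fall nearer compound 3 or compound 4 remains open. So does whether the same change would give a similar step on the core of compound 1.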